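The source may hold more compounds than are shown below. What is called first, only, known or untested is meant among the compounds shown, and "the series" means these compounds.

Measured compounds in an assay on isolated protein for inhibition of DNA topoisomerase 1 (Homo sapiens), with a stated time of 30 min, tested at 100 uM; on this read-out lower numbers stand for less inhibition and higher numbers for more inhibition at the one concentration tested (going by the name of the read-out):
- compound 1, `Cc1ccsc1-c1cc(-c2ccoc2)cc(-c2ccc(Cl)cc2)n1`: 85.9%
- compound 2, `Cc1ccsc1-c1cc(-c2ccc(Cl)o2)cc(-c2ccco2)n1`: 7.8%
- compound 3, `Cc1ccsc1-c1cc(-c2ccc(Cl)o2)cc(-c2cccc(Cl)c2)n1`: 5.9%

Compound 3 stands at the lowest of the three numbers in this assay. Among the compounds with values here, its nearest neighbour is compound 2, and the one single-point step in the set, a number 1.9 percentage points lower from compound 2 to compound 3 (within the scatter), lies within the scatter, so the two cannot be ordered. Within the data shown here, compound 1 stands far above both; it differs from compound 3 in two places and no single step connects them, so its value shows only that a member of the series carrying 4-chlorophenyl can reach a high number.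

Compound 4, `Cc1ccsc1-c1cc(-c2ccc(Cl)o2)cc(-c2ccc(Cl)cc2)n1`, differs from compound 3 by 4-chlorophenyl in place of 3-chlorophenyl on an aromatic carbon. Among the measured compounds shown here, no measured step moves the chlorine on a phenyl ring, so nothing bears directly on this change. For the measured compounds named here, the one step on this carbon, a number 1.9 percentage points lower from compound 2 to compound 3 (within the scatter), was within the scatter, which argues for a small step; the high number of compound 1, 85.9%, with the same 4-chlorophenyl but a different second ring, leaves room for a larger one. The expectation for this assay is therefore a modest rise with wide uncertainty, a number 29.1 percentage points higher from compound 3 to compound 4 (beyond the scatter).

Compound 4 is estimated at 35%, expected between 5% and 80%.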

Compound 4, a percentage reported as inhibition, at one concentration (the size of the read-out at that concentration, not a potency): 5.1%
Estimate against measurement, compound 4: 29.9 percentage points above; the measured number falls inside the stated range.
By their numbers in this assay, from the lowest: compounds 4, 3 and 2 (each within the scatter of the next); then compound 1.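

In this assay, on the carbon next to the ring nitrogen and with 5-chlorofuran-2-yl held constant, moving the chlorine from 3-chlorophenyl to 4-chlorophenyl gives a number 0.8 percentage points lower from compound 3 to compound 4 (within the scatter) and 4-chlorophenyl in place of furan-2-yl gives a number 2.7 percentage points lower from compound 2 to compound 4 (within the scatter) so furan-2-yl, 3-chlorophenyl and 4-chlorophenyl cannot be told apart at this position in this setting. With 4-chlorophenyl held constant, 5-chlorofuran-2-yl in place of furan-3-yl gives a number 80.8 percentage points lower from compound 1 to compound 4 (beyond the scatter) so 4-chlorophenyl does not by itself go with a high number in this assay and the large difference in this set lies with the furan ring on the other carbon. No independent measurement is available to account for either the flat steps or the large one.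

Still open, going by these compounds, is whether the large step follows the chlorine on the furan, the furan's point of attachment or both, as the two furan groups differ in both respects. Also open, on these data alone, is whether furan-3-yl would leave the carbon next to the ring nitrogen as flat, and how an amine or a carboxylic acid on the phenyl ring would read in this assay.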